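A Further Methoxy to Hydroxy Step on the Shared Core

A few compounds are considered here, and "the series" means these few. Any claim that something is new, unique, unknown or untested is made for them only; others in the source may bear on it.

In a functional assay on cells (Erythrocyte, Homo sapiens) for inhibition, read by spectrophotometry and hemolysis, with a stated time of 10 min (a higher number here means a weaker inhibitor, a lower number a stronger inhibitor), compound 1 `COc1cc(/C=N/NC(=O)CCc2nc3ccccc3c(=O)[nH]2)cc(OC)c1OC` gives 682000000 nM and compound 2 `COc1cc(/C=N/NC(=O)CCc2nc3ccccc3c(=O)[nH]2)cc(OC)c1O` gives 530000000 nM, so the two stand within the scatter of each other. Compound 3 `COc1cc(/C=N/NC(=O)CCc2nc3ccccc3c(=O)[nH]2)cc(O)c1O` differs from compound 2 by hydrogen in place of methyl on an oxygen on an aromatic ring. Among the measured compounds shown here, the one measured step of this kind, a 1.3-fold lower number from compound 1 to compound 2 (0.11 log units; within the scatter), stays within the scatter, so no change beyond the scatter is expected in this assay. The expected step is a 1.1-fold lower number from compound 2 to compound 3 (0.04 log units; within the scatter). For compound 3 the estimated value is 480000000 nM, with an expected range from 220000000 nM to 1000000000 nM.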

Compound 3, half-maximal inhibitory concentration in the Erythrocyte assay: 261000000 nM
Compound 3: middle estimate off by 1.8-fold (0.26 log units), on the high side; measured number inside the range.
By their numbers in the Erythrocyte assay, from the lowest: compound 3; then compounds 2 and 1 (each within the scatter of the next).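

In the Erythrocyte assay, the second methoxy to hydroxy change gives a 2.0-fold lower number from compound 2 to compound 3 (0.31 log units; beyond the scatter), so unlike the earlier change on the shared core, this one passes the scatter, though only modestly. The same change also lowers the number in a physicochemical assay, read by spectrophotometry, with a stated time of 6 min (a lower number here means a stronger inhibitor, a higher number a weaker inhibitor), where compound 2 gives 105000000 nM and compound 3 gives 40000000 nM so that the shift appears in the physicochemical assay as well: the measured half-maximal inhibitory concentration of compound 2, 105000000 nM, and of compound 3, 40000000 nM, a 2.6-fold lower number (0.42 log units; beyond the scatter)

The compounds shown leave open whether a single hydroxy group at a different place on the aromatic ring would do the same. They also leave open what an amine or a carboxylic acid would do in place of the hydroxy group.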